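The compounds below may be only part of what the source reports. "The series", "measured", "known", "first", "only" and "open" are said of these compounds alone.

In a functional assay on HGC-27 cells (Homo sapiens) for cytotoxicity, read by MTT assay, with a stated time of 72 h (a higher number here means a weaker inhibitor, a lower number a stronger inhibitor), compound 3, with the structure `Cc1ccc(Nc2nc(SCc3ccc(C(F)(F)F)cc3)nc3ccccc23)cc1`, gives 34600 nM. Among the two numbers recorded, that is the higher one; the nearer companion is compound 2, with the structure `Cc1ccccc1Nc1nc(SCc2ccc(C(F)(F)F)cc2)nc2ccccc12`, which in this assay gives 27500 nM. Compound 1, with the structure `FC(F)(F)c1ccc(CSc2nc(Nc3ccccc3C(F)(F)F)c3ccccc3n2)cc1`, gives in this assay only a limit of > 50000 nM, as the limit of > 50000 nM in this assay, at which 1 of the 3 values shown sits, records. The step of a 1.3-fold higher number from compound 2 to compound 3 (0.10 log units; within the scatter) is a swap of the aryl group on the nitrogen on the aromatic ring and stays within the scatter. The step of an at least 1.4-fold lower number from compound 1 to compound 3 (0.15 log units; that floor lies within the scatter), another swap at that same nitrogen, has a floor that also lies within the scatter. The step of an at least 1.8-fold lower number from compound 1 to compound 2 (0.25 log units; that floor lies within the scatter) concerns a different place and bears less directly on what follows.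

Compound 4, with the structure `COc1ccc(Nc2nc(SCc3ccc(C(F)(F)F)cc3)nc3ccccc23)cc1OC`, differs from compound 3 in the change (3,4-dimethoxyphenyl in place of 4-methylphenyl on a nitrogen on an aromatic ring). The two measured swaps at this nitrogen moved the number little, so no step beyond the scatter is expected for compound 4 in this assay, and the expected step is a 1.1-fold lower number from compound 3 to compound 4 (0.03 log units; within the scatter). Accordingly, compound 4 is estimated to give 32000 nM in this assay, with a range from 10000 nM to 100000 nM.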

Compound 4, half-maximal inhibitory concentration: 17900 nM
Beside the measured number, compound 4's estimate is 1.8-fold (0.25 log units) above it; measured number inside the range.
By their numbers in this assay, from the lowest: compounds 4, 2 and 3 (each within the scatter of the next). At a limit, above all of these: compound 1.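

The swap to 3,4-dimethoxyphenyl puts oxygen atoms and hydrogen-bond acceptors on this nitrogen's aryl group, unlike the groups on compounds 1, 2 and 3, yet in this assay it gives a 1.9-fold lower number from compound 3 to compound 4 (0.29 log units; within the scatter) and a 1.5-fold lower number from compound 2 to compound 4 (0.19 log units; within the scatter). Both steps therefore leave compound 4 within the scatter of the two methylphenyl compounds, so the series still shows no measurable separation among these three aryl groups. What is new is an at least 2.7-fold lower number from compound 1 to compound 4 (0.44 log units; beyond the scatter), the only step at this position shown to lie beyond the scatter, although its true size cannot be read, as compound 1 is recorded only as a limit: the limit of > 50000 nM in this assay, at which 1 of the 4 values shown sits.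

The compounds shown leave open whether a single methoxy group would behave like the pair in compound 4, and whether an amine, a carboxylic acid or a longer alkoxy chain on this phenyl ring would give a step beyond the scatter from compound 3. They also leave open how changes elsewhere would read, since all four compounds share everything except the aryl group on this nitrogen.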